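A few compounds are considered here, and "the series" means these few. Any claim that something is new, unique, unknown or untested is made for them only; others in the source may bear on it.

Measured so far in this series:

Compound 1, `CC[C@H](C)[C@H](NC(=O)c1cccc(Cn2ccnc2)c1)C(=O)Nc1nccs1`: 17%
Compound 3, `CC[C@H](C)[C@H](NC(=O)c1cccc(Cn2ccnc2)c1)C(=O)NNS(=O)(=O)c1ccccc1`: 18%
Compound 2, `CCCCS(=O)(=O)NNC(=O)[C@@H](NC(=O)c1cccc(Cn2ccnc2)c1)[C@@H](C)CC`: "not determined" (no result reported)

In an assay on HEK293 cells for displacement of a labelled ligand from Type-2 angiotensin II receptor (Homo sapiens), tested at 10 uM (a higher number here means a stronger effect of the compound at the concentration tested, a lower number a weaker effect), compound 1 gives 17%, and in the same assay compound 3 gives 18%. For compound 2 this assay reports "not determined" (no result reported), so no number is available for it. Going by the values given here, compound 3 thus sits on one of only two numbers, and that number lies within the scatter of the other: the single measured step, a number 1 percentage points higher from compound 1 to compound 3 (within the scatter), does not separate the two compounds. Compound 3 cannot be called stronger than compound 1 on this basis.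

Compound 4, `CC[C@H](C)[C@H](NC(=O)c1cccc(Cn2ccnc2)c1)C(=O)NNS(=O)(=O)c1ccc(C)cc1`, is the next entry and differs from compound 3 as follows: methyl in place of hydrogen on an aromatic carbon. Among the compounds with values here, no measured step touches this part of the molecule. Within the data shown here, the only step known, a number 1 percentage points higher from compound 1 to compound 3 (within the scatter), concerns the group on the amide-type nitrogen rather than the six-membered aromatic ring, and it was within the scatter. There is therefore nothing in the present numbers to suggest that methyl in place of hydrogen on an aromatic carbon moves the read-out in either direction. The expectation for compound 4 is accordingly a step of no change at the digits printed from compound 3 to compound 4 (within the scatter), that is, none beyond the scatter. Compound 4 is estimated in this assay at 18%, with a range from 5% to 32%.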

Compound 4, a percentage reported as inhibition, at one concentration (the size of the read-out at that concentration, not a potency): 20%
Beside the measured number, compound 4's estimate is 2 percentage points below it, and the stated range covers the measured number.
By their numbers in this assay, from the lowest: compounds 1, 3 and 4 (each within the scatter of the next).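

In this assay, the ring carbon para to a large group on the phenylsulfonyl unit now has a measured step: methyl in place of hydrogen gives a number 2 percentage points higher from compound 3 to compound 4 (within the scatter), so phenyl and 4-methylphenyl are not separated by this read-out at the one concentration tested. Exchanging 1,3-thiazol-2-yl on the amide-type nitrogen for ((4-methylphenyl)sulfonyl)amino gives a number 3 percentage points higher from compound 1 to compound 4 (within the scatter), which adds a second substituted form of that nitrogen that cannot be told apart from the 1,3-thiazol-2-yl amide in this assay. Nothing available explains these small steps or bears on the result beyond the numbers themselves.

On these data alone, whether a different group on the same ring carbon, such as an amine or a carboxylic acid, or the same methyl on another carbon of the ring, would give a step beyond the scatter remains open. Also open, as far as these compounds go, is whether a change in the shared core, such as a longer chain in place of its branched side chain, would move the read-out more than the changes on the amide-type nitrogen have.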